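This account rests on a few compounds, and the source may have more. Where it says the series, first, only, none or still open, it means among the compounds named here.

Measured so far in a functional assay on HBL-100 cells (Homo sapiens) for inhibition, read by sulforhodamine B assay, with a stated time of 48 h; on this read-out lower numbers stand for stronger inhibition of growth and higher numbers for weaker inhibition of growth:
- compound 1 `CC(=O)OC/C(=C\c1ccc(Cl)cc1)C(=O)c1ccccc1` gives 2300 nM
- compound 2 `CC(=O)OC/C(=C\c1ccc(F)cc1)C(=O)c1ccccc1` gives 17000 nM
- compound 3 `CC(=O)OC/C(=C\c1ccccc1Br)C(=O)c1ccccc1` gives 22000 nM

Compound 3 has the highest number of the three: a 9.6-fold higher number from compound 1 to compound 3 (0.98 log units; beyond the scatter), whereas a 1.3-fold higher number from compound 2 to compound 3 (0.11 log units; within the scatter). Compound 4 `CC(=O)OC/C(=C\c1ccccc1F)C(=O)c1ccccc1` differs from compound 3 by fluoro in place of bromo on an aromatic carbon. Among the measured compounds shown here, the only measured halogen swap of this kind is a 7.4-fold higher number from compound 1 to compound 2 (0.87 log units; beyond the scatter), but that one sits on a different position of the ring, and no step here exchanges bromo itself, so its bearing is loose. Weighing that, compound 4 is expected to move a little further toward weaker growth inhibition, a 1.6-fold higher number from compound 3 to compound 4 (0.20 log units; within the scatter), a shift that may well stay inside the scatter. The estimate for compound 4 in this assay is 35000 nM, within a range of 12000 nM to 100000 nM.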

Compound 4, concentration for 50% growth inhibition: 17000 nM
Estimate against measurement, compound 4: 2.1-fold (0.31 log units) above; low and high end bracket the measured number.
By their numbers in this assay, from the lowest: compound 1; then compounds 2, 4 and 3 (each within the scatter of the next).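

In this assay, among the compounds shown here, fluoro in place of bromo on this ring carbon gives a 1.3-fold lower number from compound 3 to compound 4 (0.11 log units; within the scatter) and so leaves the two halogens indistinguishable here, which the earlier compounds could not show. The fluoro compounds also stand level, with no change at the digits printed from compound 2 to compound 4 (within the scatter) as the step between them. Compound 1 alone stays apart, with a 7.4-fold higher number from compound 1 to compound 4 (0.87 log units; beyond the scatter) as its step to the new compound.

No supporting measurement bears on why these numbers fall as they do. From the compounds shown here alone, whether an amine or a methoxy group on this carbon would match the halogens stays open.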